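The source may report more compounds than this note shows. Statements on the series, on what has been measured and on what is new or still open speak of the compounds shown alone.

Compound 1 `CCO[C@H]1CC[C@H]2CCN(C)[C@H]2C1` stands only at a limit: in an assay on HEK293 cells for antagonist activity at Neuronal acetylcholine receptor; alpha3/beta4 (Rattus norvegicus), read by FLIPR, using a membrane potential dye (on this read-out higher numbers stand for weaker inhibition and lower numbers for stronger inhibition), compound 1 gives > 300000 nM, which is a limit of the assay and not a number. Compound 2 `CN1CC[C@@H]2CC[C@H](OCc3ccccc3)C[C@@H]21` gives > 300000 nM in this assay, again a limit. Compound 3 `COCCO[C@H]1CC=C2CCN(C)[C@H]2C1` gives > 300000 nM in this assay, also a limit. Among the measured compounds shown here, the single one-place step recorded, a step that the two limits leave unreadable from compound 1 to compound 2, cannot be sized, because of the limit of > 300000 nM in this assay, at which 3 of the 3 values shown sit.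

Compound 4 `CN1CC[C@@H]2CC[C@H](O)C[C@@H]21` differs from compound 1 by hydrogen in place of ethyl on an oxygen on a saturated carbon. For the measured compounds named here, no measured step bears directly on this change; the step from compound 1 to compound 2 is the only one recorded and it is unreadable. With all three shown values resting at the limit, the expectation for compound 4 is that its value also sits at the limit, and a step that the limit leaves unreadable from compound 1 to compound 4 is expected, which is no step beyond the scatter. Compound 4 is estimated at 400000 nM, with a range from 100000 nM to 2000000 nM.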

Compound 4, half-maximal inhibitory concentration: > 300000 nM
Compound 4: a limit, no number (the forecaster's own chance of this, stated with the estimate: 85%); the middle value does not contradict the limit.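

In this assay compound 4 gives > 300000 nM as a limit of the assay and not a number. No size can be read for the change from compound 1 to compound 4: the limit of > 300000 nM in this assay, at which 4 of the 4 values shown sit. The compounds shown leave open which change to the shared core would bring this assay to a readable value.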